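The compounds below may be only part of what the source reports. "The series", "measured", "known", "first", "only" and "open" are said of these compounds alone.

In a functional assay on HeLa cells (Homo sapiens) for antiproliferative activity, with a stated time of 24 h (on this read-out higher numbers stand for weaker inhibition and lower numbers for stronger inhibition), compound 3 `NC(=O)c1c(NC(=O)c2ccccc2Cl)sc2c1CCN(C(=S)Nc1cccc3ccccc13)C2` gives 30800 nM, the lowest of the two numbers shown, with compound 1 `NC(=O)c1c(NC(=O)c2ccccc2Cl)sc2c1CCN(Cc1ccccc1)C2` nearest at 38400 nM, a gap within the scatter. Compound 2 `Cc1ccccc1CN1CCc2c(sc(NC(=O)c3ccccc3Cl)c2C(N)=O)C1` reaches only the limit of this assay at > 50000 nM. Among the measured compounds shown here, the one measured step, an at least 1.3-fold higher number from compound 1 to compound 2 (0.11 log units; that floor lies within the scatter), lies within the scatter and tells nothing about the thiourea side of the core. Compound 4 `NC(=O)c1c(NC(=O)c2ccccc2Cl)sc2c1CCN(C(=S)Nc1ccccc1Br)C2` carries 2-bromophenyl in place of naphthalen-1-yl on an amide-type nitrogen. For the measured compounds named here, no measured step touches this part of the molecule, so no shift beyond the scatter is expected, and the step from compound 3 to compound 4 is estimated as a 1.0-fold lower number from compound 3 to compound 4 (0.01 log units; within the scatter). For compound 4 the expected value in this assay is 30000 nM, between 10000 nM and 60000 nM.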

Compound 4, half-maximal inhibitory concentration: 24600 nM
The estimate for compound 4 lay 1.2-fold (0.09 log units) above the measured number, within the range that was stated.
By their numbers in this assay, from the lowest: compounds 4, 3 and 1 (each within the scatter of the next). At a limit, above all of these: compound 2.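

In this assay, the step on the amide-type nitrogen, a 1.3-fold lower number from compound 3 to compound 4 (0.10 log units; within the scatter), shows that 2-bromophenyl and naphthalen-1-yl are not told apart at this position, even though one ring replaces two. On the amine nitrogen in a ring, a 1.6-fold lower number from compound 1 to compound 4 (0.19 log units; within the scatter) and an at least 2.0-fold lower number from compound 2 to compound 4 (0.30 log units; that floor lies within the scatter) likewise leave the groups there unseparated. Compound 2 is held only at a limit, not a number: the limit of > 50000 nM in this assay, at which 1 of the 4 values shown sits.

From the compounds shown here alone, it remains open whether an amine or a carboxylic acid on that phenyl ring would move the number beyond the scatter. The same holds for a longer chain in place of the ring.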